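Moving the indole link from compound 2 to compound 3

The compounds below may be only part of what the source reports. "The series", "measured", "known", "first", "only" and "open" are said of these compounds alone.

In a functional assay on DU-145 cells (Homo sapiens) for inhibition, read by trypan blue exclusion, with a stated time of 72 h (on this read-out lower numbers stand for stronger inhibition and higher numbers for weaker inhibition), compound 2 (`COc1ccc(S(=O)(=O)c2cc3cnc(Nc4ccc5[nH]ccc5c4)nc3n(C)c2=O)cc1`) gives 500 nM and compound 1 (`Cn1c(=O)c(S(=O)(=O)c2ccc(F)cc2F)cc2cnc(Nc3cccc4[nH]ccc34)nc21`) gives 750 nM as its result. These two numbers lie within the usual scatter of repeated measurements, so compound 2 cannot be told apart from compound 1 on present evidence.

The next compound to be tested is compound 3 (`COc1ccc(S(=O)(=O)c2cc3cnc(Nc4cccc5[nH]ccc45)nc3n(C)c2=O)cc1`). It differs from compound 2 in one place: 1H-indol-4-yl in place of 1H-indol-5-yl on a nitrogen on an aromatic ring. The two compounds have the same atoms, joined differently, so this change alters a connection and adds nothing new.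

For the measured compounds named here, no measured pair isolates this kind of change, so there is no direct precedent for its size or direction. The guess therefore starts from compound 2 at 500 nM and keeps a wide margin. The step of a 1.2-fold higher number from compound 2 to compound 3 (0.08 log units; within the scatter) is expected to stay within the scatter, with no clear gain or loss. For compound 3 the estimated value is 600 nM with a range expected to run from 200 nM to 1800 nM at this early stage.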

Compound 3, half-maximal inhibitory concentration: 5000 nM
Beside the measured number, compound 3's estimate is 8.3-fold (0.92 log units) below it, and the stated range ends below it.
By their numbers in this assay, from the lowest: compounds 2 and 1 (each within the scatter of the next); then compound 3.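

In this assay, the indole link turns out to matter: 1H-indol-4-yl in place of 1H-indol-5-yl on the same nitrogen gives a 10-fold higher number from compound 2 to compound 3 (1.00 log units; beyond the scatter), even though the two compounds have the same atoms, joined differently. The group on the sulfonyl sulfur matters too, at least while 1H-indol-4-yl is held fixed, since 4-methoxyphenyl in place of 2,4-difluorophenyl gives a 6.7-fold higher number from compound 1 to compound 3 (0.82 log units; beyond the scatter). So two separate places on this scaffold can each shift the number beyond the scatter, though nothing at hand explains either step.

Going by these compounds, it remains open whether the penalty for moving the indole link is the same with 2,4-difluorophenyl on the sulfonyl sulfur as with 4-methoxyphenyl, so the two changes cannot yet be said to act independently. On these data alone, it is also open how 1H-indol-6-yl, or a plain phenyl on that nitrogen, would compare with the two indoles seen so far.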